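The compounds below may be only part of what the source reports. "The series", "measured", "known", "first", "only" and "open" are said of these compounds alone.

Working notes on a small set sharing one core. In a functional assay on NUGC-3 cells (Homo sapiens) for antiproliferative activity, read by sulforhodamine B assay (on this read-out higher numbers stand for weaker inhibition of growth and lower numbers for stronger inhibition of growth), compound 1 `Cc1cc(C)c2sc(NC(=O)c3ccc(C(F)(F)F)cc3)nc2c1` gives 1.4 ug/mL. Compound 2 `COc1ccc(C(=O)Nc2nc3c(OC)cccc3s2)cc1` gives 3.46 ug/mL in this assay. Compound 3 `COc1ccccc1NC(=O)Nc1nc2ccc(F)cc2s1` returns only a limit in this assay, > 10 ug/mL, so no number is known for it. Compound 3 thus stands at the limit of > 10 ug/mL in this assay, at which 1 of the 3 values shown sits, the weak end of the values shown, while compounds 1 and 2 each have a number. The next compound, compound 4 `O=C(Nc1ccccc1)Nc1nc2ccc(F)cc2s1`, differs from compound 3 by hydrogen in place of methoxy on an aromatic carbon, the change sitting on the six-membered aromatic ring of carbon only, ortho to a large group. Within the data shown here, no pair of measured compounds differs in a single place, so no measured step shows how large such a change runs in this assay. Compound 3 itself gives no number to build on, only its limit. The expectation is that compound 4 stays weak, and the expected step that the limit leaves unreadable from compound 3 to compound 4 is none beyond the scatter in this assay. Compound 4 is therefore estimated at 12 ug/mL, within 4 ug/mL to 40 ug/mL, with a real chance that this assay again reports only a limit and no number.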

Compound 4, concentration for 50% growth inhibition: > 10 ug/mL
Compound 4 gave a limit, no number; the forecaster's own chance of this, stated with the estimate: 65%; the middle value is on the limit's open side.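

Compound 3 and compound 4 each return only a limit in this assay, so no step between them can be read: the limit of > 10 ug/mL in this assay, at which 2 of the 4 values shown sit.

The compounds shown leave open how strongly either compound inhibits growth, and whether hydrogen in place of methoxy on an aromatic carbon changes the read-out in this assay at all.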